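From 2,4-dimethylphenyl to 3-fluoro-4-methoxyphenyl on the shared core

The source may report more compounds than this note shows. Statements on the series, on what has been measured and on what is new or still open speak of the compounds shown alone.

Compound 1 `CCC1=C(O)c2c(oc(-c3ccc(O)cc3)cc2=O)C(CC)(CC)C1=O`: 20.6 uM
Compound 2 `CCC1=C(O)c2c(oc(-c3cccc(OC)c3)cc2=O)C(CC)(CC)C1=O`: 13.3 uM
Compound 3 `CCC1=C(O)c2c(oc(-c3ccc(C)cc3C)cc2=O)C(CC)(CC)C1=O`: 41.2 uM

In a functional assay on KB cells (Homo sapiens) for antiproliferative activity, read by sulforhodamine B assay, with a stated time of 3 days (a higher number here means that more compound is needed for the effect, a lower number that less compound is needed), compound 3 gives 41.2 uM, which lies within the scatter of compound 1 and apart only from compound 2. The two measured steps are a 2.0-fold higher number from compound 1 to compound 3 (0.30 log units; within the scatter) and a 3.1-fold higher number from compound 2 to compound 3 (0.49 log units; beyond the scatter). Compound 4 `CCC1=C(O)c2c(oc(-c3ccc(OC)c(F)c3)cc2=O)C(CC)(CC)C1=O` has 3-fluoro-4-methoxyphenyl in place of 2,4-dimethylphenyl on an aromatic carbon. Within the data shown here, the closest precedent is compound 2, whose 3-methoxyphenyl gives way to 2,4-dimethylphenyl in that larger step, while a 1.5-fold lower number from compound 1 to compound 2 (0.19 log units; within the scatter) suggests the other two aryl groups sit close together. A modest move to a lower number is therefore expected, and the estimated step is a 2.3-fold lower number from compound 3 to compound 4 (0.36 log units; beyond the scatter). For compound 4 the estimated value is 18 uM, with an expected range of 8 uM to 40 uM.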

Compound 4, concentration for half-maximal effect: 26.7 uM
Compound 4: middle estimate off by 1.5-fold (0.17 log units), on the low side; measured number inside the range.
By their numbers in this assay, from the lowest: compounds 2, 1, 4 and 3 (each within the scatter of the next, the first and the last beyond it).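

In this assay the change to 3-fluoro-4-methoxyphenyl gives a 1.5-fold lower number from compound 3 to compound 4 (0.19 log units; within the scatter) and so stays within the scatter of 2,4-dimethylphenyl. The same aryl group also shows a 2.0-fold higher number from compound 2 to compound 4 (0.30 log units; within the scatter) and a 1.3-fold higher number from compound 1 to compound 4 (0.11 log units; within the scatter) so that it sits within the scatter of every other aryl group tested here, and only compound 2 and compound 3 remain apart. Nothing available points to a cause for this narrow spread. Going by these compounds, it remains open whether an aminophenyl or carboxyphenyl group, or a longer alkyl chain in place of the aryl ring, would move the number beyond this band.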